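Swapping an Anilide for a Pyrrolidine Amide

The source may hold more compounds than are shown below. What is called first, only, known or untested is meant among the compounds shown, and "the series" means these compounds.

Compound 1 `Cc1ccc(NC(=O)c2cccc(/C=C3\CC(=O)N(c4ccccc4)C3=O)c2)cc1` was tested in an ADME assay on SW480 cells (Homo sapiens) for cytotoxicity, read by MTT assay, with a stated time of 72 h; on this read-out lower numbers stand for stronger inhibition and higher numbers for weaker inhibition. Compound 1 gives only a limit there, > 100000 nM, so no number is known for it. Compound 2 `COc1cc(NC(=O)c2cccc(/C=C3\CC(=O)N(c4ccccc4)C3=O)c2)cc(OC)c1OC` likewise returns only a limit, > 100000 nM. Every value shown thus sits at the limit of > 100000 nM in this assay, at which 2 of the 2 values shown sit. Compound 3 `O=C(c1cccc(/C=C2\CC(=O)N(c3ccccc3)C2=O)c1)N1CCCC1` is not yet measured; it differs from compound 1 in one place: pyrrolidin-1-yl in place of (4-methylphenyl)amino on a carbonyl carbon. Within the data shown here, with no measured step of this kind to lean on, the change is expected to bring no shift beyond the scatter, a number no higher from compound 1 to compound 3 (the limit leaves the size open). Compound 3 is therefore expected to give about 100000 nM, within a range from 40000 nM to 300000 nM, and most likely again only a limit.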

Compound 3, half-maximal inhibitory concentration: > 100000 nM
Compound 3: no number, only a limit; the forecaster's own chance of this, stated with the estimate: 75%; the middle value lies on the limit itself.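

Among these compounds, compound 1 and compound 3 both end at a limit rather than a number, so no step between them can be read: the limit of > 100000 nM in this assay, at which 3 of the 3 values shown sit. As far as these compounds go, whether pyrrolidin-1-yl or (4-methylphenyl)amino gives stronger inhibition, and by how much, stays open.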